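From formyl to methyl on the aromatic nitrogen

The source may hold more compounds than are shown below. What is called first, only, known or untested is meant among the compounds shown, and "the series" means these compounds.

Measured in a functional assay on the whole organism with Mus musculus as the target; on this read-out lower numbers stand for an effect already at smaller amounts and higher numbers for an effect only at larger amounts of compound:
Compound 1 `Cc1c(C)c2c(c(C)c1N)CC(C)(CSCc1ccccc1)O2`: 32 mg/kg
Compound 2 `Cc1c(C)c2c(c(C)c1NC=O)CC(C)(C)O2`: > 100 mg/kg

Compound 2 stands at > 100 mg/kg, which is a limit of the assay and not a number.

Compound 3 `CNc1c(C)c(C)c2c(c1C)CC(C)(C)O2` differs from it by methyl in place of formyl on a nitrogen on an aromatic ring, with methyl in place of formyl on a nitrogen on an aromatic ring. Compound 1, which carries no formyl on its nitrogen, gives 32 mg/kg, so a sizeable step towards smaller doses is expected in this assay, though with wide uncertainty. The expected change is an at least 2.5-fold lower number from compound 2 to compound 3 (0.39 log units; beyond the scatter). For compound 3 the estimated value is 40 mg/kg, with an expected range of 12 mg/kg to 100 mg/kg.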

Compound 3, dose for 50% inhibition: 16.6 mg/kg
Estimate against measurement, compound 3: 2.4-fold (0.38 log units) above, within the range that was stated.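

Methyl in place of formyl on the aromatic nitrogen gives the first direct comparison at this position: in this assay, the change reads as an at least 6.0-fold lower number from compound 2 to compound 3 (0.77 log units; beyond the scatter). With methylamino in place of formylamino, the core of compound 3 gives a measured dose on this read-out. The value of compound 2 is a limit of the assay and not a number, and the step has no fixed upper end: the limit of > 100 mg/kg in this assay, at which 1 of the 3 values shown sits. The compounds shown leave open how an unsubstituted amine, an ethylamino group or an acetylamino group would read on the core of compound 3.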